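Cyclopentyl hydrazone at the core of compound 1

A few compounds are considered here, and "the series" means these few. Any claim that something is new, unique, unknown or untested is made for them only; others in the source may bear on it.

Measured compounds:
compound 1 `Nc1nc(N/N=C/c2ccc3ncccc3c2)nc2c1ncn2[C@@H]1O[C@H](CO)[C@@H](O)[C@H]1O` — 9.8 nM
compound 2 `Nc1nc(N/N=C/c2ccc(C(F)(F)F)cc2C(F)(F)F)nc2c1ncn2[C@@H]1O[C@H](CO)[C@@H](O)[C@H]1O` — > 10000 nM

Going by the values given here, in an assay on CHO-K1 cells for displacement of a labelled ligand from adenosine receptor A1 (Homo sapiens), read by scintillation counting, with a stated time of 60 min (on this read-out higher numbers stand for weaker inhibition and lower numbers for stronger inhibition), compound 1 gives 9.8 nM, the only plain number among the two values at hand. Compound 2 returns only > 10000 nM, which is a limit of this assay and not a number; that limit is described by the limit of > 10000 nM in this assay, at which 1 of the 2 values shown sits. Nothing further can be said of the gap between compound 1 and compound 2 beyond what these two values show.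

Compound 3 `Nc1nc(N/N=C/C2CCCC2)nc2c1ncn2[C@@H]1O[C@H](CO)[C@@H](O)[C@H]1O` has not yet been measured in this assay. It differs from compound 1 in one place: cyclopentyl in place of quinolin-6-yl on a carbon with a double bond to nitrogen. Among the compounds with values here, no step between measured compounds tells how much this change should matter. The expectation is that the step of a 12-fold higher number from compound 1 to compound 3 (1.09 log units; beyond the scatter) will go toward weaker inhibition and lie beyond the usual scatter. Compound 3 is therefore estimated at 120 nM, within a range from 15 nM to 1500 nM.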

Compound 3, inhibition constant: 5.6 nM
Compound 3: the middle estimate sits 21-fold (1.33 log units) above what was measured, and the stated range ends above it.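

Cyclopentyl in place of quinolin-6-yl gives a 1.8-fold lower number from compound 1 to compound 3 (0.24 log units; within the scatter) in this assay. On this carbon with a double bond to nitrogen, then, neither an aromatic ring nor the ring nitrogen of quinolin-6-yl is needed for inhibition at this level, as a five-membered non-aromatic ring of carbon only serves equally well in this pair. Nothing in the data at hand gives a cause for this result.

With a single non-aromatic ring shown, it remains open whether cyclohexyl, cyclopropyl or an open chain such as n-butyl on the same carbon would keep this level of inhibition. Also open, as far as these compounds go, is what an amine or a carboxylic acid on the cyclopentyl ring would do to the value.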